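Swapping the Benzoyl Group for a Cyclopentylmethyl Carbonyl

The source may report more compounds than this note shows. Statements on the series, on what has been measured and on what is new or still open speak of the compounds shown alone.

Compound 1 `O=C(Nc1cc(-c2ccccc2)nn1-c1ccccc1)c1ccccc1` is the weaker of the two compounds with a full number in an assay on HEK293 cells for displacement of a labelled ligand from metabotropic glutamate receptor 5 (Rattus norvegicus) (a lower number here means a stronger inhibitor, a higher number a weaker inhibitor), where compound 1 gives 4180 nM. Compound 2 `O=C(Nc1cc(-c2ccccc2)nn1-c1ccccc1Cl)c1ccccc1` gives 500 nM in this assay, a step of an 8.4-fold lower number from compound 1 to compound 2 (0.92 log units; beyond the scatter). Compound 3 `N#Cc1cccc(-n2nc(-c3ccccc3)cc2NC(=O)c2ccccc2)c1` falls at the limit of > 10000 nM in this assay, at which 1 of the 3 values shown sits. For compound 3 the result > 10000 nM is a limit of the assay and not a number. Compound 4 `O=C(CC1CCCC1)Nc1cc(-c2ccccc2)nn1-c1ccccc1` differs from compound 1 by cyclopentylmethyl in place of phenyl on a carbonyl carbon. Every measured step among compound 1, compound 2 and compound 3 changes the aryl group on the nitrogen of the shared core, as in an at least 2.3-fold higher number from compound 1 to compound 3 (0.37 log units; beyond the scatter) and an at least 20-fold higher number from compound 2 to compound 3 (1.30 log units; beyond the scatter); none of them touches the carbonyl side, so none bears directly on this change. With nothing to point either way, the step from compound 1 to compound 4 in this assay is expected to stay close to the scatter, a change of a 1.0-fold lower number from compound 1 to compound 4 (0.02 log units; within the scatter). For compound 4 the expected value in this assay is 4000 nM, within a range from 1200 nM to 13000 nM.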

Compound 4, inhibition constant: > 10000 nM
Compound 4: no number, only a limit (the forecaster's own chance of this, stated with the estimate: 25%); middle value at least 2.5-fold (0.39 log units) from the limit.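

The carbonyl side of the shared core now has a measured step of its own: in this assay, cyclopentylmethyl in place of phenyl on a carbonyl carbon gives an at least 2.3-fold higher number from compound 1 to compound 4 (0.37 log units; beyond the scatter). The earlier steps shown here all changed the aryl group on the nitrogen, so they could not show that this side also responds to change, here beyond the scatter even though the group entering has the same count of heavy atoms as the group leaving. Compound 4 gives > 10000 nM, which is a limit of the assay and not a number, so the full size of the step stays unknown: the limit of > 10000 nM in this assay, at which 2 of the 4 values shown sit.

The compounds shown do not separate the loss of the aromatic ring from the added methylene link, which a cyclopentyl or a benzyl on the carbonyl carbon could tell apart. Going by these compounds, how a chlorobenzoyl or an aminobenzoyl would read at this position also remains open.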